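A few compounds are considered here, and "the series" means these few. Any claim that something is new, unique, unknown or untested is made for them only; others in the source may bear on it.

In a functional assay (a higher number here means a weaker inhibitor, a lower number a stronger inhibitor), compound 1 (`CC(C)=CCOc1ccc2c(c1)OC(c1cccc(F)c1)CC2=O`) gives 4280 nM and compound 2 (`CC(C)=CCOc1ccc2c(c1)OC(c1ccccc1Cl)CC2=O`) gives 8020 nM while compound 3 (`CC(C)=CCOc1ccc2c(c1)OC(c1ccc(Br)cc1)CC2=O`) gives 8120 nM on the same scale. These three values sit within the scatter of one another, so compound 3 has no clear place among them. Compound 4 (`CC(C)=CCOc1ccc2c(c1)OC(c1ccc(O)cc1)CC2=O`) differs from compound 3 by hydroxy in place of bromo on an aromatic carbon, para to a large group (hydroxy in place of bromo on an aromatic carbon). Among the compounds with values here, the steps that bear on this change all alter the same phenyl group: a 1.9-fold higher number from compound 1 to compound 3 (0.28 log units; within the scatter) and a 1.0-fold higher number from compound 2 to compound 3 (0.01 log units; within the scatter) and also a 1.9-fold higher number from compound 1 to compound 2 (0.27 log units; within the scatter) in the same series. Within the data shown here, none of them leaves the scatter, and no measured compound carries a hydroxy, so they offer only loose guidance. No step beyond the scatter is therefore expected in this assay in either direction, though the range has to stay wide. The expected change in this estimate is a 1.4-fold lower number from compound 3 to compound 4 (0.13 log units; within the scatter) and no more. For compound 4 the estimated value is 6000 nM with an expected range from 2000 nM to 16000 nM in this read-out.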

Compound 4, half-maximal inhibitory concentration: 6670 nM
For compound 4 the middle estimate is 1.1-fold (0.05 log units) below the measured one, within the range that was stated.
By their numbers in this assay, from the lowest: compounds 1, 4, 2 and 3 (each within the scatter of the next).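

Exchanging bromo for hydroxy on an aromatic carbon, para to a large group, adds a hydrogen-bond donor and a hydrogen-bond acceptor, yet the result in this assay stays within the scatter (a 1.2-fold lower number from compound 3 to compound 4 (0.09 log units; within the scatter)). The 4-hydroxyphenyl group also stays within the scatter of the other two phenyl groups (a 1.2-fold lower number from compound 2 to compound 4 (0.08 log units; within the scatter); a 1.6-fold higher number from compound 1 to compound 4 (0.19 log units; within the scatter)). Across these four compounds, this position accepts a hydroxy as readily as a halogen, and no step shows a preference among the four phenyl groups. Nothing available explains why this exchange leaves the result within the scatter. From the compounds shown here alone, whether an amine or a carboxylic acid in the same place would move the number beyond the scatter remains open. So does whether a methoxy or a longer chain there would do so.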